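The source may report more compounds than this note shows. Statements on the series, on what has been measured and on what is new or still open speak of the compounds shown alone.

Of the compounds shown here, three built on a shared core have been measured in a functional assay on HUVEC cells (Homo sapiens) for inhibition, with stated times of 2 h and 72 h; a lower number here means a stronger inhibitor, a higher number a weaker inhibitor. Compound 3 (`COc1ccc(C(=O)Nc2nn(C)c3cc(Oc4ccnc5cc(OC)c(OC)cc45)ccc23)cc1`) gives 32 nM and compound 1 (`COc1cc2nccc(Oc3ccc4c(NC(=O)c5cc(C(F)(F)F)cc(C(F)(F)F)c5)nn(C)c4c3)c2cc1OC`) gives 58 nM, two values within the usual scatter of each other. Compound 2 (`COc1cc2nccc(Oc3ccc4c(NC(=O)Nc5ccc(C(F)(F)F)cc5Cl)nn(C)c4c3)c2cc1OC`) gives 1150 nM, well above both. Compound 3 therefore sits in the low pair of these numbers.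

Compound 4 (`COc1ccc(NC(=O)Nc2nn(C)c3cc(Oc4ccnc5cc(OC)c(OC)cc45)ccc23)cc1`) differs from compound 3 in one place: (4-methoxyphenyl)amino in place of 4-methoxyphenyl on a carbonyl carbon. Put simply, (4-methoxyphenyl)amino stands in place of 4-methoxyphenyl on a carbonyl carbon.

Within the data shown here, one measured step bears on this change: a 36-fold lower number from compound 2 to compound 3 (1.56 log units; beyond the scatter). That step also has 4-methoxyphenyl in place of an arylamino group on a carbonyl carbon, so compound 4 restores the amino link in the opposite direction. However, the aromatic group differs in that step too, since (2-chloro-4-(trifluoromethyl)phenyl)amino is the group that leaves. Among the measured compounds shown here, no measured pair separates these two parts. Only a portion of that large step is therefore expected to return, towards a higher number in this assay, and the uncertainty is wide. The expected change is a 4.1-fold higher number from compound 3 to compound 4 (0.61 log units; beyond the scatter). For compound 4 the estimated value is 130 nM, with an expected range from 30 nM to 600 nM.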

Compound 4, half-maximal inhibitory concentration: 7 nM
For compound 4 the middle estimate is 19-fold (1.27 log units) above the measured one; the whole stated range lies above it.
By their numbers in this assay, from the lowest: compound 4; then compounds 3 and 1 (each within the scatter of the next); then compound 2.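

In this assay, changing only the group on the carbonyl carbon from 4-methoxyphenyl to (4-methoxyphenyl)amino gives a 4.6-fold lower number from compound 3 to compound 4 (0.66 log units; beyond the scatter), so with this aromatic group the amino link goes with a stronger inhibitor, not a weaker one. Keeping the amino link and changing only the aromatic group, with 4-methoxyphenyl in place of 2-chloro-4-(trifluoromethyl)phenyl on an amide-type nitrogen, gives a 160-fold lower number from compound 2 to compound 4 (2.22 log units; beyond the scatter), so the large gap seen earlier between compound 2 and compound 3 belongs to the aromatic group rather than to the link. Nothing in the data shown gives a reason for either step.

Among these compounds, the gain from the amino link is seen only with 4-methoxyphenyl, and no compound here puts 2-chloro-4-(trifluoromethyl)phenyl directly on the carbonyl carbon, so whether the link acts the same way with that group remains open. Also open, on these data alone, is how a methylene carbon or a methylamino group would compare with the amino link, and how a hydroxyl group or a chlorine would compare with the methoxy group on the aromatic ring.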